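Chain homologation in a menthyl amide series

A few compounds are considered here, and "the series" means these few. Any claim that something is new, unique, unknown or untested is made for them only; others in the source may bear on it.

Compound 1 `Cc1ccc(C(=O)N[C@@H]2C[C@H](C)CC[C@H]2C(C)C)cc1` gives 2200 nM in a functional assay on HEK293 cells for antagonist activity at transient receptor potential cation channel subfamily M member 8 (Rattus norvegicus), read by calcium flux; a higher number here means a weaker inhibitor, a lower number a stronger inhibitor.
Compound 2 `CC(C)[C@@H]1CC[C@@H](C)C[C@H]1NC(=O)c1ccc(-c2ccccc2)cc1` gives 20 nM in this assay.
Compound 3 `CC(C)[C@@H]1CC[C@@H](C)C[C@H]1NC(=O)CCCCCCc1ccccc1` gives 400 nM in this assay.

Compound 3 stands second highest of the three numbers: compound 1 sits above it and compound 2 below it, both beyond the scatter. Compound 4 `CC(C)[C@@H]1CC[C@@H](C)C[C@H]1NC(=O)CCCCCCCc1ccccc1` differs from compound 3 by benzyl in place of phenyl on a saturated chain carbon, six bonds along the chain from a carbonyl carbon, so the chain that links the carbonyl to the aromatic ring grows by one carbon.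

For the measured compounds named here, only one step among the measured compounds is defined, a 110-fold lower number from compound 1 to compound 2 (2.04 log units; beyond the scatter), and it concerns an aromatic substituent on the benzamide, not a chain extension; it does not bear directly on the change from compound 3 to compound 4. The values of compound 1 and compound 3 merely show that a long chain ending in phenyl gives a lower number than a small aromatic substituent. Going by the values given here, no measured pair tests one extra methylene in a flexible chain. The step of no change at the digits printed from compound 3 to compound 4 (within the scatter) is therefore expected to be small, with no direction resolved beyond the scatter. Compound 4 is estimated at 400 nM, with a range from 150 nM to 1100 nM.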

Compound 4, half-maximal inhibitory concentration: 400 nM
For compound 4 middle estimate and measured number coincide at the digits printed, within the range that was stated.
By their numbers in this assay, from the lowest: compound 2; then compounds 3 and 4 (each within the scatter of the next); then compound 1.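

In this assay, adding one carbon to the chain that links the carbonyl to the aromatic ring, read as benzyl in place of phenyl on a saturated chain carbon, six bonds along the chain from a carbonyl carbon, gives no change at the digits printed from compound 3 to compound 4 (within the scatter). For the compounds shown here, this is the first measured pair to test a single added carbon in the flexible chain, whereas the only earlier step, a 110-fold lower number from compound 1 to compound 2 (2.04 log units; beyond the scatter), concerned a substituent on the aromatic ring of the benzamide and said nothing about chain length. At this position and length the extra carbon leaves the number within the scatter, although no data available here bear on why that is so.

Going by these compounds, one step gives no trend across chain lengths, so whether a longer chain or a much shorter one would hold the number in this range remains open. Also open, on these data alone, is how this assay would respond to an amine or a carboxylic acid on the chain, or to a fluorine or a methoxy group on the aromatic ring at its end.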